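The source may report more compounds than this note shows. Statements on the series, on what has been measured and on what is new or still open speak of the compounds shown alone.

Two compounds of the series have so far been run in a functional assay on WiDr cells (Homo sapiens) for inhibition, read by sulforhodamine B assay, with a stated time of 48 h; on this read-out lower numbers stand for stronger inhibition of growth and higher numbers for weaker inhibition of growth. Compound 1 `COC(=O)[C@@]1(C)CCC=C2[C@@H]1CC[C@@H](C)[C@]2(C)Cc1c(C)[nH]c2ccc(C)cc12` gives 28000 nM in this assay. Compound 2 `COC(=O)[C@@]1(C)CCC=C2[C@@H]1CC[C@@H](C)[C@]2(C)Cc1c(C)[nH]c2ccc(Br)cc12` gives 15000 nM in this assay. Going by the values given here, the only step so far, a 1.9-fold lower number from compound 1 to compound 2 (0.27 log units; within the scatter), is bromo in place of methyl on an aromatic carbon, and it stays within the scatter, so no ranking of compound 1 against compound 2 can be read from it. Compound 2 stands with the lowest of the two numbers, the nearest being compound 1, within the scatter.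

Compound 3 `COC(=O)[C@@]1(C)CCC=C2[C@@H]1CC[C@@H](C)[C@]2(C)Cc1c(C)[nH]c2ccc(Cl)cc12` is the next member. The change from compound 2 to compound 3 is chloro in place of bromo on an aromatic carbon, on an aromatic carbon of a six-membered aromatic ring of carbon only, part of a fused or bridged system of two rings. Among the compounds with values here, no measured step in this assay involves a chloro group, and the one step that does touch this carbon stayed within the scatter. The step of a 1.2-fold higher number from compound 2 to compound 3 (0.08 log units; within the scatter) is therefore expected to stay within the scatter as well. Compound 3 is estimated at 18000 nM in this assay, with a range from 8000 nM to 40000 nM.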

Compound 3, concentration for 50% growth inhibition: 18000 nM
The estimate for compound 3 equals the measured number at the digits printed, within the range that was stated.
By their numbers in this assay, from the lowest: compounds 2, 3 and 1 (each within the scatter of the next).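

In this assay the exchange of bromo for chloro gives a 1.2-fold higher number from compound 2 to compound 3 (0.08 log units; within the scatter) on this aromatic carbon, and chloro in place of methyl on the same carbon gives a 1.6-fold lower number from compound 1 to compound 3 (0.19 log units; within the scatter) in the same series. With a second halogen now in the set, methyl, bromo and chloro on this carbon all lie within the scatter of one another, so no order can be drawn among compound 1, compound 2 and compound 3, and neither halogen can be separated from methyl. No supporting measurement on these compounds bears on this result.

The three compounds leave open whether a group of another kind on this carbon, such as an amine, a carboxylic acid, a methoxy group or a longer chain, would move the number beyond the scatter, or whether this position simply has little bearing on growth inhibition in this cell line. They also leave open how fluoro or a bare hydrogen would read here, and whether changes elsewhere on the shared core, such as replacing the methyl ester with a carboxylic acid, would shift the number more.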